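Exchanging pyrrolidin-1-yl for 5-methyl-1H-imidazol-1-yl

The source may hold more compounds than are shown below. What is called first, only, known or untested is meant among the compounds shown, and "the series" means these compounds.

In a functional assay on the whole organism for antagonist activity, with Mus musculus as the target (a higher number here means that more compound is needed for the effect, a lower number that less compound is needed), compound 3 (`CCOC(=O)N(C)C(C)C#CCN1CCCC1`) gives 97 mg/kg as the highest of the three numbers. Compound 2 (`COC(=O)N(C)C(C)C#CCn1cncc1C`) with 3.7 mg/kg and compound 1 (`CC(=O)N(C)C(C)C#CCn1cncc1C`) with 1.1 mg/kg lie well below it, beyond the scatter. Compound 4 (`CCOC(=O)N(C)C(C)C#CCn1cncc1C`) carries 5-methyl-1H-imidazol-1-yl in place of pyrrolidin-1-yl on a saturated chain carbon bound to a triple-bonded carbon. Among the measured compounds shown here, no measured pair isolates this exchange. For the measured compounds named here, the only measured step of a 3.4-fold higher number from compound 1 to compound 2 (0.53 log units; beyond the scatter) lies at the carbonyl end and is modest, so compound 4 is expected to stay near compound 2 and compound 1, which both carry the entering group. A large fall in this assay is therefore expected, and the estimated step of a 12-fold lower number from compound 3 to compound 4 (1.08 log units; beyond the scatter) reflects that. For compound 4 the estimate is 8 mg/kg (expected range 3 mg/kg to 25 mg/kg).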

Compound 4, dose for half-maximal effect: 9.7 mg/kg
The estimate for compound 4 lay 1.2-fold (0.08 log units) below the measured number; low and high end bracket the measured number.
By their numbers in this assay, from the lowest: compound 1; then compound 2; then compound 4; then compound 3.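

In this assay the exchange now has its own pair, and a 10-fold lower number from compound 3 to compound 4 (1.00 log units; beyond the scatter) comes with 5-methyl-1H-imidazol-1-yl in place of pyrrolidin-1-yl on a saturated chain carbon bound to a triple-bonded carbon, with the ethoxy end held constant. With the entering group kept, the carbonyl end still counts: a 2.6-fold higher number from compound 2 to compound 4 (0.42 log units; beyond the scatter) goes with methoxy giving way to ethoxy, and an 8.8-fold higher number from compound 1 to compound 4 (0.95 log units; beyond the scatter) goes with methyl giving way to ethoxy at that end. As far as these compounds go, whether the exchange has the same size with methyl or methoxy on the carbonyl carbon stays open, as does the effect of propoxy there. No evidence on the cause of these steps is available.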